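The compounds below may be only part of what the source reports. "The series", "measured", "known", "first", "only" and "open" are said of these compounds alone.

Measured compounds:
compound 1 `O=C(/C=C/c1ccccc1)N[C@@H](CCCCCC(=O)NO)C(=O)NCc1ccccc1`, 460 nM
compound 2 `O=C(CCCCC[C@H](NC(=O)OCc1ccccc1)C(=O)NCc1ccccc1)NO`, 1520 nM
compound 3 `O=C(CCCCC[C@H](NC(=O)c1cc2c(O)cccc2[nH]1)C(=O)NCc1ccccc1)NO`, 330 nM

In a functional assay on MM96L cells (Homo sapiens) for antiproliferative activity (a lower number here means a stronger inhibitor, a higher number a weaker inhibitor), compound 2 gives the highest number of the three: the step of a 3.3-fold higher number from compound 1 to compound 2 (0.52 log units; beyond the scatter) leads up to it, and the step of a 4.6-fold lower number from compound 2 to compound 3 (0.66 log units; beyond the scatter) leads down again. Compound 4 `O=C(CCCCC[C@H](NC(=O)OCc1ccccc1)C(=O)Nc1ccc(-c2ccccc2)cc1)NO` differs from compound 2 by 4-phenylphenyl in place of benzyl on an amide-type nitrogen. Within the data shown here, all three measured steps change the group on the carbonyl carbon of the shared core; none touches the amide nitrogen, so no measured step bears directly on this change. The expectation therefore rests on the untouched hydroxamic acid end alone: compound 4 is expected to stay within the scatter of compound 2, the step of a 1.5-fold lower number from compound 2 to compound 4 (0.18 log units; within the scatter), giving an estimated 1000 nM with a range from 250 nM to 4000 nM.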

Compound 4, half-maximal inhibitory concentration: 330 nM
For compound 4 the middle estimate is 3.0-fold (0.48 log units) above the measured one; the measured number falls inside the stated range.
By their numbers in this assay, from the lowest: compounds 3, 4 and 1 (each within the scatter of the next); then compound 2.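

In this assay, among these compounds, the group on the amide-type nitrogen turns out to matter: 4-phenylphenyl in place of benzyl gives a 4.6-fold lower number from compound 2 to compound 4 (0.66 log units; beyond the scatter) and so the number moves at this place too, while the earlier steps all changed the group on the carbonyl carbon. The entering group has 12 heavy atoms against 7 and a second aromatic ring, but nothing measured here explains the step.

As far as these compounds go, whether 4-phenylphenyl gives a similar step on compound 1 or compound 3 remains open. So does the outcome with a plain phenyl or a pyridine ring on this nitrogen.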